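The compounds below may be only part of what the source reports. "The series", "measured", "known", "first", "only" and "open" are said of these compounds alone.

Among the measured compounds shown here, in a functional assay on M21 cells (Homo sapiens) for antiproliferative activity, read by sulforhodamine B assay, with a stated time of 48 h (on this read-out lower numbers stand for stronger inhibition and higher numbers for weaker inhibition), compound 2 (`O=C1NCCN1c1ccc(S(=O)(=O)Nc2ccccc2)cc1`) gives 200 nM and compound 1 (`Cc1ccc(NS(=O)(=O)c2ccc(N3CCNC3=O)cc2)cc1`) gives 260 nM as the only other number. The two values lie within the scatter of each other, so neither compound ranks ahead.

Compound 3 (`Cc1cc(C)cc(NS(=O)(=O)c2ccc(N3CCNC3=O)cc2)c1`) carries 3,5-dimethylphenyl in place of phenyl on a sulfonamide nitrogen and has not yet been measured.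

For the measured compounds named here, only one measured step bears on this change: hydrogen in place of methyl on an aromatic carbon (a 1.3-fold lower number from compound 1 to compound 2 (0.11 log units; within the scatter)), which stays within the scatter. Going by the values given here, that step concerns a single methyl, whereas compound 3 carries two, and no measured compound has the 3,5-dimethylphenyl group. The evidence is therefore thin, and it gives no ground for a direction.

For compound 3 the expected outcome in this assay is no step beyond the scatter, with the estimated change being (a 1.3-fold higher number from compound 2 to compound 3 (0.10 log units; within the scatter)) and no more.

For compound 3 the estimated value is 250 nM with an expected range from 90 nM to 700 nM in this series.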

Compound 3, half-maximal inhibitory concentration: 63 nM
Compound 3: the middle estimate sits 4.0-fold (0.60 log units) above what was measured; measured number outside the range, below it.
By their numbers in this assay, from the lowest: compound 3; then compounds 2 and 1 (each within the scatter of the next).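

Working from this assay, the group on the sulfonamide nitrogen can move the number beyond the scatter: 3,5-dimethylphenyl in place of phenyl gives a 3.2-fold lower number from compound 2 to compound 3 (0.50 log units; beyond the scatter) here, whereas the earlier swap of 4-methylphenyl for phenyl stayed within it. Set against 4-methylphenyl, the same group gives a 4.1-fold lower number from compound 1 to compound 3 (0.62 log units; beyond the scatter) and so, among these three compounds, phenyl and 4-methylphenyl read alike while 3,5-dimethylphenyl stands apart, with compound 3 holding the lowest number of the series so far. The step is modest in size, and nothing at hand bears on why this group lowers the number.

The compounds shown leave open whether both methyl groups are needed for the step, since no compound here separates the contribution of each one, and whether larger groups such as ethyl or isopropyl in their place would extend it or lose it. Also open, going by these compounds, is whether methoxy, chloro or an amine on that ring would give a similar number, and whether the step would hold on any change to the rest of the core of compound 3.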